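The source may hold more compounds than are shown below. What is called first, only, known or untested is meant among the compounds shown, and "the series" means these compounds.

Measured in a functional assay on BCG823 cells (Homo sapiens) for inhibition, read by MTT assay, with a stated time of 72 h; on this read-out lower numbers stand for stronger inhibition and higher numbers for weaker inhibition:
compound 1 `CN(C(=O)NC(=O)c1ccc(F)c(F)c1)c1nc(C(F)(F)F)c(C(=O)N/N=C/c2ccccc2C(F)(F)F)s1` — 3.66 ug/mL
compound 2 `CN(C(=O)NC(=O)c1ccc(F)c(F)c1)c1nc(C(F)(F)F)c(C(=O)N/N=C/c2cccc(C(F)(F)F)c2)s1` — 4.46 ug/mL

Compound 1 gives the smaller of the two numbers, but the step of a 1.2-fold higher number from compound 1 to compound 2 (0.09 log units; within the scatter) shows the two values sit within the scatter of each other; the series gives no spread beyond it. Compound 3 `CN(C(=O)NC(=O)c1ccccc1F)c1nc(C(F)(F)F)c(C(=O)N/N=C/c2ccccc2C(F)(F)F)s1` carries the change (2-fluorophenyl in place of 3,4-difluorophenyl on a carbonyl carbon). Among the measured compounds shown here, no measured step touches this carbonyl-side ring: the only step, between compound 1 and compound 2, lies on the other end of the shared core and was within the scatter. Nothing here supports a shift in either direction, so compound 3 is estimated at 3.8 ug/mL (range 1.5 ug/mL to 10 ug/mL). The expected step of a 1.0-fold higher number from compound 1 to compound 3 (0.02 log units; within the scatter) is thus within the scatter, with wide uncertainty.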

Compound 3, half-maximal inhibitory concentration: 4.67 ug/mL
Beside the measured number, compound 3's estimate is 1.2-fold (0.09 log units) below it; the measured number falls inside the stated range.
By their numbers in this assay, from the lowest: compounds 1, 2 and 3 (each within the scatter of the next).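

In this assay the ring on the carbonyl carbon now has a measured step of its own: a 1.3-fold higher number from compound 1 to compound 3 (0.11 log units; within the scatter) for 2-fluorophenyl in place of 3,4-difluorophenyl. The shared core has now been changed at both ends, and neither change separates compound 2 or compound 3 from compound 1. No supporting data bear on this result.

Going by these compounds, what an amine or a carboxylic acid on this phenyl ring would do to the read-out stays open. These compounds also show no step beyond the scatter at either end.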